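This account rests on a few compounds, and the source may have more. Where it says the series, first, only, none or still open, it means among the compounds named here.

Measured compounds in a physicochemical assay for solubility, using the shake flask method, in phosphate buffer, measured as kinetic solubility, with a stated time of 20 h, at pH 6.5; a higher number here means a more soluble compound, a lower number a less soluble compound:
Compound 1, `COc1cccnc1Nc1cc2[nH]c(-c3cccc(C(F)(F)F)c3)nc2cn1`: compound 1 gives < 5000 nM, a limit of the assay rather than a number.
Compound 2, `FC(F)(F)c1cccc(-c2nc3cnc(Nc4cnccn4)cc3[nH]2)c1`: compound 2 gives < 5000 nM, likewise a limit.
Compound 3, `N#Cc1ccc(Nc2cc3[nH]c(-c4cccc(C(F)(F)F)c4)nc3cn2)nc1`: compound 3 gives < 5000 nM, again a limit.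

Compound 1 therefore stands nowhere definite on the numbers shown: it sits at the limit of < 5000 nM in this assay, at which 3 of the 3 values shown sit, as do the other two. The steps between the measured compounds, a step that the two limits leave unreadable from compound 1 to compound 2, a step that the two limits leave unreadable from compound 1 to compound 3 and a step that the two limits leave unreadable from compound 2 to compound 3, all exchange the group on the same ring nitrogen, and none can be sized because every value involved is the limit of < 5000 nM in this assay, at which 3 of the 3 values shown sit.

Compound 4, `FC(F)(F)c1ccc(Nc2cc3[nH]c(-c4cccc(C(F)(F)F)c4)nc3cn2)nc1`, differs from compound 1 at that same place: 5-(trifluoromethyl)pyridin-2-yl in place of 3-methoxypyridin-2-yl on a nitrogen on an aromatic ring. All three measured steps bear on this position, yet none of them is readable, so no direction or size beyond the scatter can be drawn from them. The expected step that the limit leaves unreadable from compound 1 to compound 4 is accordingly set as no readable change. Compound 4 is estimated at 2000 nM in this assay, with a range from 400 nM to 5000 nM, and it is expected most likely to come back as a limit again.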

Compound 4, solubility: < 5000 nM
Compound 4: only a limit was reported (the forecaster's own chance of this, stated with the estimate: 85%); the middle value does not contradict the limit.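

In this assay compound 4 gives < 5000 nM, a limit of the assay, so its steps from compound 1, compound 2 and compound 3 cannot be read: the limit of < 5000 nM in this assay, at which 4 of the 4 values shown sit.

The compounds shown leave open how these four compounds rank and how far each lies from that limit.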